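Shifting the hydroxy group around the hydrazone aryl ring

The compounds below may be only part of what the source reports. "The series", "measured", "known", "first", "only" and "open" are said of these compounds alone.

Measured compounds:
compound 1 `Cn1c(=O)c(=O)n(C2CCCC2)c2nc(N/N=C/c3ccc(O)cc3)ncc21`: 72500 nM
compound 2 `Cn1c(=O)c(=O)n(C2CCCC2)c2nc(N/N=C/c3ccc(C(F)(F)F)cc3)ncc21`: 29000 nM

In a functional assay on HCT-116 cells (Homo sapiens) for antiproliferative activity, read by MTT assay (on this read-out higher numbers stand for weaker inhibition and lower numbers for stronger inhibition), compound 1 gives 72500 nM, the highest of the two numbers shown. Compound 2 gives 29000 nM, and the step of a 2.5-fold lower number from compound 1 to compound 2 (0.40 log units; beyond the scatter) is the only measured one. Compound 3 `Cn1c(=O)c(=O)n(C2CCCC2)c2nc(N/N=C/c3cccc(O)c3)ncc21` differs from compound 1 by 3-hydroxyphenyl in place of 4-hydroxyphenyl on a carbon with a double bond to nitrogen. Among the compounds with values here, the single measured step swaps hydroxy for trifluoromethyl and does not move a group around the ring, so it bears only loosely on this change. Compound 3 is therefore expected to sit close to compound 1, with an estimated step of a 1.2-fold lower number from compound 1 to compound 3 (0.08 log units; within the scatter). Compound 3 is estimated at 60000 nM, within a range of 25000 nM to 150000 nM.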

Compound 3, half-maximal inhibitory concentration: 37200 nM
Beside the measured number, compound 3's estimate is 1.6-fold (0.21 log units) above it, and the stated range covers the measured number.
By their numbers in this assay, from the lowest: compounds 2, 3 and 1 (each within the scatter of the next, the first and the last beyond it).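

With 3-hydroxyphenyl in place of 4-hydroxyphenyl, this assay shows a 1.9-fold lower number from compound 1 to compound 3 (0.29 log units; within the scatter), so moving the hydroxy group gives no difference beyond the scatter. Compound 3 also stands level with the trifluoromethyl analogue, with a 1.3-fold higher number from compound 2 to compound 3 (0.11 log units; within the scatter), which places it within the scatter of both compound 1 and compound 2, although those two lie beyond the scatter of each other. Nothing available explains these numbers. As far as these compounds go, whether an amine or a methoxy group on this aryl ring would give a clearly different number remains open.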